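Compound 3: 4-fluorophenyl in place of 2-fluorophenyl

The source may hold more compounds than are shown below. What is called first, only, known or untested is meant among the compounds shown, and "the series" means these compounds.

Measured in an ADME assay on HepG2 cells (Homo sapiens) for cytotoxicity, in the presence of a further agent that is not named here; on this read-out higher numbers stand for weaker inhibition and lower numbers for stronger inhibition:
Compound 1 (`Cn1c(Cc2ccccc2C(F)(F)F)nc(C(=O)NCC2CCCCC2)c(O)c1=O`) gives > 100000 nM as a limit
Compound 2 (`Cn1c(Cc2ccccc2C(F)(F)F)nc(C(=O)NCc2ccccc2F)c(O)c1=O`) gives > 100000 nM as a limit

In this assay compound 2 stands at > 100000 nM as a limit of the assay, not a number. Among the measured compounds shown here, the only measured step, a step that the two limits leave unreadable from compound 1 to compound 2 here, cannot be sized, and the evidence amounts to the limit of > 100000 nM in this assay, at which 2 of the 2 values shown sit, and no more. Compound 3 (`Cn1c(Cc2ccccc2C(F)(F)F)nc(C(=O)NCc2ccc(F)cc2)c(O)c1=O`) carries this change: 4-fluorophenyl in place of 2-fluorophenyl on a saturated chain carbon bound to an amide-type nitrogen with 4-fluorophenyl in place of 2-fluorophenyl on a saturated chain carbon bound to an amide-type nitrogen. Since compound 2 gives > 100000 nM as a limit, no step beyond the scatter and no direction is expected in this assay for this change. The estimated a number no higher from compound 2 to compound 3 (the limit leaves the size open) is expected to stay within the scatter. Compound 3 is expected near 100000 nM with an estimated range from 50000 nM to 200000 nM and will probably again be reported only as a limit.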

Compound 3, half-maximal inhibitory concentration: > 100000 nM
Compound 3 ended at the assay's limit; the forecaster's own chance of this, stated with the estimate: 85%; the middle value sits exactly at the limit.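

In this assay compound 3 gives > 100000 nM, a limit and not a number, so the steps among compound 1, compound 2 and compound 3 cannot be read. The compounds shown leave open what concentration of any of the three would reach half-maximal inhibition.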